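Swapping furan for thiophene on the shared core

The source may hold more compounds than are shown below. What is called first, only, known or untested is meant among the compounds shown, and "the series" means these compounds.

Measured in a functional assay on THP-1 cells (Homo sapiens) for inhibition, read by ELISA, with stated times of 1 h and 18 h; a higher number here means a weaker inhibitor, a lower number a stronger inhibitor
- compound 1 `NC(=O)[C@@H]1[C@H](Nc2nc(Nc3cccc(C(=O)N4CCCC4)c3)ncc2-c2cccnc2)[C@H]2C=C[C@@H]1C2` gives 320 nM
- compound 2 `Cc1cnc(Nc2cccc(C(=O)N3CCCC3)c2)nc1N[C@H]1[C@@H](C(N)=O)[C@@H]2C=C[C@H]1C2` gives 100 nM
- compound 3 `NC(=O)[C@@H]1[C@H](Nc2nc(Nc3cccc(C(=O)N4CCCC4)c3)ncc2-c2ccoc2)[C@H]2C=C[C@@H]1C2` gives 40 nM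

Compound 3 has the lowest of these three numbers, which makes it the strongest inhibitor so far, and its gaps to both other compounds lie beyond the scatter. The next structure, compound 4 `NC(=O)[C@@H]1[C@H](Nc2nc(Nc3cccc(C(=O)N4CCCC4)c3)ncc2-c2ccsc2)[C@H]2C=C[C@@H]1C2`, keeps the shared core and changes one group: thiophen-3-yl in place of furan-3-yl on an aromatic carbon. In plain terms, thiophen-3-yl stands in place of furan-3-yl on an aromatic carbon, so oxygen gives way to sulfur as the hetero atom of the five-membered aromatic ring.

Three measured steps involve changes on this same carbon. Methyl in place of pyridin-3-yl gave a 3.2-fold lower number from compound 1 to compound 2 (0.51 log units; beyond the scatter). Furan-3-yl in place of pyridin-3-yl gave an 8.0-fold lower number from compound 1 to compound 3 (0.90 log units; beyond the scatter). Furan-3-yl in place of methyl gave a 2.5-fold lower number from compound 2 to compound 3 (0.40 log units; beyond the scatter). All three are modest, and none compares two five-membered rings, so the data cannot size this swap directly. The new group differs far less from furan-3-yl than methyl or pyridin-3-yl does, so little change is expected in this assay. The estimated step is a 1.3-fold higher number from compound 3 to compound 4 (0.10 log units; within the scatter), which would not stand clear of the scatter.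

For compound 4 the estimated value is 50 nM, with an expected range from 20 nM to 130 nM.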

Compound 4, half-maximal inhibitory concentration: 110 nM
The estimate for compound 4 lay 2.2-fold (0.34 log units) below the measured number; the range from low to high includes it.
By their numbers in this assay, from the lowest: compound 3; then compounds 2 and 4 (each within the scatter of the next); then compound 1.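

Exchanging oxygen for sulfur leaves the heavy-atom, donor and acceptor counts of the group the same, yet in this assay this swap gives a 2.8-fold higher number from compound 3 to compound 4 (0.44 log units; beyond the scatter) and so takes the number beyond the scatter, which shows that this position can respond to the identity of a single ring atom and that the result for furan-3-yl does not carry over to every five-membered aromatic ring. The comparison with the small group is also changed, since thiophen-3-yl gives a 1.1-fold higher number from compound 2 to compound 4 (0.04 log units; within the scatter) and stays within the scatter of methyl, so among these compounds only furan-3-yl stands clear of methyl, while the step of a 2.9-fold lower number from compound 1 to compound 4 (0.46 log units; beyond the scatter) keeps thiophen-3-yl, like furan-3-yl and methyl, on the lower side of pyridin-3-yl. Nothing available here accounts for the gap between the oxygen ring and the sulfur ring.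

Still open, on these data alone, is how this carbon would respond to an amine, a carboxylic acid or a longer chain such as propyl. Also open, as far as these compounds go, is whether furan-2-yl or thiophen-2-yl, joined through a different ring carbon, would keep the same order between oxygen and sulfur.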